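The source may hold more compounds than are shown below. What is called first, only, known or untested is meant among the compounds shown, and "the series" means these compounds.

In a functional assay on the whole organism with Scenedesmus acutus as the target (a higher number here means a weaker inhibitor, a lower number a stronger inhibitor), compound 3 (`COC(=O)c1cc(N2C(=O)C3=C(CCCC3)C2=O)c(F)cc1Cl`) gives 110 nM and sits in the middle of the three numbers. Compound 1 (`O=C1C2=C(CCCC2)C(=O)N1c1ccc(Cl)cc1F`) gives 24.6 nM as the lowest number, and compound 2 (`COC(=O)c1cc(N2C(=O)C3=C(CCCC3)C2=O)ccc1Cl`) gives 2000 nM as the highest. Compound 4 (`CCCCOC(=O)c1cc(N2C(=O)C3=C(CCCC3)C2=O)c(F)cc1Cl`) carries one change (propyl in place of hydrogen on a saturated chain carbon bound to an oxygen next to a carbonyl group): propyl in place of hydrogen on a saturated chain carbon bound to an oxygen next to a carbonyl group, so methoxycarbonyl becomes butoxycarbonyl. For the measured compounds named here, two measured steps bear on this only indirectly. Adding methoxycarbonyl gave a modest step (a 4.5-fold higher number from compound 1 to compound 3 (0.65 log units; beyond the scatter)), and adding fluoro gave a large one (an 18-fold lower number from compound 2 to compound 3 (1.26 log units; beyond the scatter)). From the compounds shown here alone, neither tests chain length, so no step beyond the scatter is expected in this assay, and the direction stays open. The estimated step is a 1.1-fold lower number from compound 3 to compound 4 (0.04 log units; within the scatter) and remains uncertain. For compound 4 the expected value is 100 nM with an estimated range from 25 nM to 400 nM as a deliberately wide guess.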

Compound 4, half-maximal inhibitory concentration: 67.6 nM
Beside the measured number, compound 4's estimate is 1.5-fold (0.17 log units) above it; low and high end bracket the measured number.
By their numbers in this assay, from the lowest: compound 1; then compounds 4 and 3 (each within the scatter of the next); then compound 2.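

Changing methoxycarbonyl to butoxycarbonyl gives the first direct test of chain length at this position. In this assay the added propyl gives a 1.6-fold lower number from compound 3 to compound 4 (0.21 log units; within the scatter), so this position accepts the longer chain. Butoxycarbonyl still leaves a measurable gap to the hydrogen of the fluorinated parent (a 2.7-fold higher number from compound 1 to compound 4 (0.44 log units; beyond the scatter)), and no supporting data explain either step. A longer chain such as octyl, or a branched one such as tert-butyl, could show where this tolerance ends. From the compounds shown here alone, a carboxylic acid or an amide in place of the butoxycarbonyl group also remains open.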